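A few compounds are considered here, and "the series" means these few. Any claim that something is new, unique, unknown or untested is made for them only; others in the source may bear on it.

In an ADME assay on RAW264.7 cells (Mus musculus) for cytotoxicity, read by MTT assay, with a stated time of 24 h, in the absence of a further agent (a higher number here means a weaker inhibitor, a lower number a stronger inhibitor), compound 1 (`COc1ccc(C(O)C2OC(=O)c3c(OC)cc(OC)cc32)cc1`) gives > 40000 nM as a limit of the assay and not a number. Compound 2 (`COCCCOc1ccc(C(O)C2OC(=O)c3c(OC)cc(OC)cc32)cc1`) gives > 40000 nM as a limit too. Compound 3 (`COc1cc(OC)c2c(c1)C(C(O)c1ccc(OCc3ccc(Br)cc3)cc1)OC2=O`) gives > 40000 nM as a limit as well. Compound 3 therefore has no exact number, and it stands with the others at the limit of > 40000 nM in this assay, at which 3 of the 3 values shown sit, in the table of results.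

Compound 4 (`COc1cc(OC)c2c(c1)C(C(O)c1ccc(OCC3CCCCC3)cc1)OC2=O`) differs from compound 3 in one group (cyclohexyl in place of 4-bromophenyl on a saturated chain carbon bound to an oxygen on an aromatic ring) with cyclohexyl in place of 4-bromophenyl, so that cyclohexylmethoxy replaces (4-bromobenzyl)oxy. Among the measured compounds shown here, three measured steps touch this same place: a step that the two limits leave unreadable from compound 1 to compound 2 and a step that the two limits leave unreadable from compound 1 to compound 3 and a step that the two limits leave unreadable from compound 2 to compound 3 are the whole evidence. None has a readable size, but none of the three compounds left the limit. A step beyond the usual scatter in this assay is therefore not expected, and no direction can be favoured.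

The expected result is a step that the limit leaves unreadable from compound 3 to compound 4 and no more than that. For compound 4 the estimate is 50000 nM with an expected range from 25000 nM to 100000 nM and quite possibly only a limit again.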

Compound 4, half-maximal inhibitory concentration: > 40000 nM
Compound 4 ended at the assay's limit (the forecaster's own chance of this, stated with the estimate: 85%); the middle value lies beyond the limit too.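

Among the compounds shown here, compound 4 also stays at a limit and not a number, so no step from compound 1, compound 2 or compound 3 to compound 4 can be read: the limit of > 40000 nM in this assay, at which 4 of the 4 values shown sit.

In this assay the compounds shown leave open how strong each of these four compounds really is, and whether changing this group makes any difference.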